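Aryl swap in a weakly cytotoxic series

This account rests on a few compounds, and the source may have more. Where it says the series, first, only, none or still open, it means among the compounds named here.

The read-out is a functional assay on Ehrlich cells (Mus musculus) for cytotoxicity; on this read-out higher numbers stand for weaker inhibition and lower numbers for stronger inhibition. Three compounds on the shared core have been run. Compound 1 `COc1cc(N2C(N)=C(C#N)C(c3ccc(OC)c4ccccc34)C3=C2CC(C)(C)CC3=O)cc(OC)c1OC` was reported as "not active" (no number reported) in this assay, with no number attached. Compound 2 `COc1cc(N2C(N)=C(C#N)C(c3cccc([N+](=O)[O-])c3)C3=C2CC(C)(C)CC3=O)cc(OC)c1OC` likewise was reported as "not active" (no number reported) in this assay, again with no number attached. For the measured compounds named here, compound 3 `COc1ccccc1C1C(C#N)=C(N)N(c2cc(OC)c(OC)c(OC)c2)C2=C1C(=O)CC(C)(C)C2` gives 26600 nM in this assay; it is the only entry with a number and sits at the weak end, the two others having no value at all. Going by the values given here, no pair of measured compounds differs in one place, so no single-change step is available.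

Compound 4 `COc1cc(N2C(N)=C(C#N)C(c3ccc(O)cc3)C3=C2CC(C)(C)CC3=O)cc(OC)c1OC` is the next entry. It differs from compound 3 as follows: 4-hydroxyphenyl in place of 2-methoxyphenyl on a saturated ring carbon. With neither a measured step nor a second numbered value to lean on, the expectation rests on compound 3, whose 26600 nM marks weak inhibition, and on compound 1 and compound 2, which gave no number. Compound 4 is therefore expected to stay weak. The step of a 1.3-fold higher number from compound 3 to compound 4 (0.12 log units; within the scatter) is what the estimate means, a change expected to lie within the usual scatter. The estimate for compound 4 is 35000 nM, between 9000 nM and 120000 nM.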

Compound 4, half-maximal inhibitory concentration: 75800 nM
Beside the measured number, compound 4's estimate is 2.2-fold (0.34 log units) below it; measured number inside the range.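

In this assay the change to 4-hydroxyphenyl on the saturated ring carbon brings a 2.8-fold higher number from compound 3 to compound 4 (0.45 log units; beyond the scatter) and so gives the series its first step that lies beyond the scatter, modest in size and towards weaker inhibition. For the compounds shown here, the earlier entries offered only one number, whereas this pair shows that the read-out does respond to the aryl group at this carbon, with both numbered compounds still at the weak end. Because the swap removes the methoxy group and brings in a hydroxy group at a different place on the phenyl ring, this one step cannot assign the shift to either feature, and no supporting data bear on its origin.

Compound 1 and compound 2 carry no number, so steps involving them cannot be read. Still open, from the compounds shown here alone, is how an unsubstituted phenyl, a 2-hydroxyphenyl, a 4-methoxyphenyl, a 4-aminophenyl or a phenyl bearing a carboxylic acid would read at this carbon, and whether any group there moves the series away from the weak end.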